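This account rests on a few compounds, and the source may have more. Where it says the series, first, only, none or still open, it means among the compounds named here.

In a functional assay, read by spectrophotometry, tested at 100 uM (a higher number here means a weaker inhibitor, a lower number a stronger inhibitor), three compounds have been measured so far:
Compound 1 `Cc1ccc(/C=C/C(=O)c2cccc(NC(=O)c3cc(-c4ccncc4)n[nH]3)c2)cc1` gives 69400 nM.
Compound 2 `O=C(/C=C/c1ccc(F)cc1)c1cccc(NC(=O)c2cc(-c3ccncc3)n[nH]2)c1` gives 56000 nM.
Compound 3 `O=C(/C=C/c1cccs1)c1cccc(NC(=O)c2cc(-c3ccncc3)n[nH]2)c1` gives 27600 nM.

Compound 3 has the lowest number of the three and is the strongest inhibitor among them; its steps to the other two both lie beyond the scatter. All three share one core and differ only in the group on the double-bonded chain carbon bound to a double-bonded chain carbon. Compound 4 `COc1ccccc1/C=C/C(=O)c1cccc(NC(=O)c2cc(-c3ccncc3)n[nH]2)c1` has not yet been measured. Its change from compound 3: 2-methoxyphenyl in place of thiophen-2-yl on a double-bonded chain carbon bound to a double-bonded chain carbon. Among the measured compounds shown here, two measured steps bear on this, and both run the opposite way, from a six-membered aromatic ring of carbon only to thiophen-2-yl: a 2.5-fold lower number from compound 1 to compound 3 (0.40 log units; beyond the scatter) and a 2.0-fold lower number from compound 2 to compound 3 (0.31 log units; beyond the scatter). Each lowered the number modestly. Compound 4 goes back to a six-membered aromatic ring of carbon only, now bearing a methoxy group, so a modest rise in the number is expected, a 1.8-fold higher number from compound 3 to compound 4 (0.26 log units; within the scatter). For the measured compounds named here, no measured compound shows what a methoxy group does here, so the range is kept wide. Compound 4 is therefore estimated to give 50000 nM in this assay, between 20000 nM and 120000 nM.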

Compound 4, half-maximal inhibitory concentration: 41700 nM
Compound 4: the middle estimate sits 1.2-fold (0.08 log units) above what was measured; the range from low to high includes it.
By their numbers in this assay, from the lowest: compounds 3, 4, 2 and 1 (each within the scatter of the next, the first and the last beyond it).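

In this assay, a 2-methoxyphenyl group on a double-bonded chain carbon bound to a double-bonded chain carbon gives three steps that all lie within the scatter: a 1.5-fold higher number from compound 3 to compound 4 (0.18 log units; within the scatter) and a 1.3-fold lower number from compound 2 to compound 4 (0.13 log units; within the scatter) and a 1.7-fold lower number from compound 1 to compound 4 (0.22 log units; within the scatter). This ring, the first here to carry a methoxy group, therefore cannot be separated from thiophen-2-yl, 4-fluorophenyl or 4-methylphenyl, and compound 3 can no longer be called the strongest inhibitor of the set. No measurement given here accounts for these steps.

An unsubstituted phenyl ring would be needed to separate the effect of the methoxy group from that of the ring carrying it. As far as these compounds go, whether an amine or a carboxylic acid on this ring would move the number beyond the scatter also remains open.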